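The compounds below may be only part of what the source reports. "The series", "measured", "known", "first", "only" and "open" are said of these compounds alone.

In a functional assay on Ehrlich cells (Mus musculus) for cytotoxicity, tested at 25 ug/mL (a higher number here means a stronger effect of the compound at the concentration tested, a lower number a weaker effect), the three measured compounds gave:

Compound 1 `COc1cc(N2C(N)=C(C#N)C(c3ccc(OC)c4ccccc34)C3=C2CC(C)(C)CC3=O)cc(OC)c1OC`: 30%
Compound 2 `COc1cc(N2C(N)=C(C#N)C(c3cccc([N+](=O)[O-])c3)C3=C2CC(C)(C)CC3=O)cc(OC)c1OC`: 20%
Compound 3 `COc1cc(N2C(N)=C(C#N)C(c3ccc(C)o3)C3=C2CC(C)(C)CC3=O)cc(OC)c1OC`: 31%

On these numbers compound 1 lies between the other two, yet neither gap is beyond the scatter: a number 1 percentage points higher from compound 1 to compound 3 (within the scatter) and a number 10 percentage points lower from compound 1 to compound 2 (within the scatter). Among the compounds with values here, only the step of a number 11 percentage points higher from compound 2 to compound 3 (beyond the scatter) is modest and beyond it.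

Compound 4 `COc1cc(N2C(N)=C(C#N)C(c3ccccc3)C3=C2CC(C)(C)CC3=O)cc(OC)c1OC` is the next variation at the same saturated ring carbon: phenyl in place of 4-methoxynaphthalen-1-yl on a saturated ring carbon. The two steps that bear on this change, from compound 1 to compound 2 and from compound 1 to compound 3, both swap the group at that carbon and both stay within the scatter. A step of that size, none beyond the scatter in this assay, is therefore expected here as well, so that compound 4 is estimated at 27%, with a range from 15% to 40%, which means an expected step of a number 3 percentage points lower from compound 1 to compound 4 (within the scatter).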

Compound 4, a percentage reported as activity, at one concentration (the size of the read-out at that concentration, not a potency): 6%
Beside the measured number, compound 4's estimate is 21 percentage points above it; measured number outside the range, below it.
By their numbers in this assay, from the lowest: compound 4; then compounds 2, 1 and 3 (each within the scatter of the next, the first and the last beyond it).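

Phenyl at this saturated ring carbon stands apart in this assay with a number 24 percentage points lower from compound 1 to compound 4 (beyond the scatter) and a number 25 percentage points lower from compound 3 to compound 4 (beyond the scatter) and, on losing the nitro, with a number 14 percentage points lower from compound 2 to compound 4 (beyond the scatter). Within the data shown here, the group here can therefore matter more than the earlier steps suggested, and compound 4 is the weakest of the four, beyond the scatter of each other compound. No measurement shown explains this drop.

From the compounds shown here alone, whether an amino group or a hydroxyl on that phenyl would lift the number stays open, as does whether a pyridine ring in its place would behave like phenyl.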